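A few compounds are considered here, and "the series" means these few. Any claim that something is new, unique, unknown or untested is made for them only; others in the source may bear on it.

Of the compounds shown here, two have numbers so far: compound 1 `CC(C)[C@H](NC(=O)[C@H](C)N)C(=O)N1CCN(Cc2ccccc2)CC1C(=O)NC(c1ccccc1)c1ccccc1` and compound 2 `CC(C)C(NC(=O)[C@H](C)N)c1nc(C(=O)NCc2ccccc2)cs1`. In a functional assay on MDA-MB-231 cells (Homo sapiens) for cytotoxicity, with a stated time of 72 h (a lower number here means a stronger inhibitor, a higher number a weaker inhibitor), compound 1 gives 31000 nM. Compound 2 gives > 50000 nM, and that reading is a limit of the assay, not a number. Compound 2 therefore stands at the limit of > 50000 nM in this assay, at which 1 of the 2 values shown sits.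

The next molecule, compound 3 `CC(C)C(NC(=O)[C@H](C)N)c1nc(C(=O)NCc2ccccc2)c(-c2ccccc2)s1`, differs from compound 2 in one place: phenyl in place of hydrogen on an aromatic carbon. In words, phenyl replaces hydrogen on an aromatic carbon, next to the ring sulfur and next to the ring atom that bears a benzylcarbamoyl group.

Going by the values given here, no measured pair shows what such a change does, so any expectation here is modest. Compound 1 at 31000 nM shows that a compound of this kind can give a real number in this assay, so compound 3 is expected to land in that region rather than far beyond it. The expected change is an at least 1.6-fold lower number from compound 2 to compound 3 (0.22 log units; that floor lies within the scatter), a small gain in strength at best, and another reading at the limit would be no surprise. For compound 3 the estimated value is 30000 nM, with an expected range from 9000 nM to 60000 nM.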

Compound 3, half-maximal inhibitory concentration: > 50000 nM
Compound 3: no number, only a limit (the forecaster's own chance of this, stated with the estimate: 45%); at least 1.6-fold (0.22 log units) between middle value and limit.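

Compound 2 and compound 3 both end at a limit of this assay rather than at a number, so the effect of phenyl in place of hydrogen on an aromatic carbon cannot be read from this pair: the limit of > 50000 nM in this assay, at which 2 of the 3 values shown sit.

The compounds shown leave open whether this change alters strength in cells at all, and in which direction.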